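This account rests on a few compounds, and the source may have more. Where it says the series, first, only, none or still open, it means among the compounds named here.

Measured so far in a functional assay on ECa-109 cells for inhibition, with ECa-109 cell line (Homo sapiens) as the target, read by MTT assay, with a stated time of 48 h; on this read-out higher numbers stand for weaker inhibition and lower numbers for stronger inhibition:

compound 1 `COc1ccc(-c2coc3cc(OCCCSC(=S)N4CCOCC4)ccc3c2=O)cc1` gives 34000 nM
compound 2 `COc1ccc(-c2coc3cc(OCCCCSC(=S)N4CCN(C(=O)OC(C)(C)C)CC4)ccc3c2=O)cc1` gives 8840 nM
compound 3 `COc1ccc(-c2coc3cc(OCCSC(=S)N4CCN(C(=O)OC(C)(C)C)CC4)ccc3c2=O)cc1` gives 4090 nM

Compound 1 stands at the highest number of the three. Its gap to compound 2 lies beyond the usual scatter, and its larger gap to compound 3 lies beyond the usual scatter as well. Compound 1 is the weakest inhibitor among the measured set. For the measured compounds named here, the two lower numbers belong to the compounds that carry a piperazine bearing a tert-butoxycarbonyl group rather than a morpholine, though their linker lengths also differ from compound 1, so no single-change step between measured compounds is available.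

Compound 4 `COc1ccc(-c2coc3cc(OCCCSC(=S)N4CCN(C)CC4)ccc3c2=O)cc1` keeps the three-carbon linker of compound 1 and changes only the amine part: 4-methylpiperazin-1-yl in place of morpholin-4-yl on a thiocarbonyl carbon. Compound 4 is expected to give a somewhat lower number than compound 1, a step of a 2.8-fold lower number from compound 1 to compound 4 (0.45 log units; beyond the scatter) beyond the scatter but modest, without a measured single-change step to anchor it. The estimate for compound 4 in this assay is 12000 nM, with a range from 3000 nM to 40000 nM.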

Compound 4, half-maximal inhibitory concentration: 24200 nM
Compound 4: the middle estimate sits 2.0-fold (0.30 log units) below what was measured, within the range that was stated.
By their numbers in this assay, from the lowest: compound 3; then compound 2; then compounds 4 and 1 (each within the scatter of the next).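

In this assay, for the compounds shown here, this is the first single-change reading: with the linker and the shared core held fixed, 4-methylpiperazin-1-yl in place of morpholin-4-yl on a thiocarbonyl carbon is a 1.4-fold lower number from compound 1 to compound 4 (0.15 log units; within the scatter). At this position, then, the two six-membered rings cannot be told apart on this read-out, and the exchange alone does not reach the lower numbers seen elsewhere in the set. No supporting data bear on why the step is this small.

Going by these compounds, whether the tert-butoxycarbonyl group on the piperazine matters remains open, since the compounds that carry it also differ in linker length. Also open, on these data alone, is how an unsubstituted piperazin-1-yl or a piperidin-1-yl ring would read on the same linker.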